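This account rests on a few compounds, and the source may have more. Where it says the series, first, only, none or still open, it means among the compounds named here.

Measured to date in an assay on isolated protein for inhibition of Amine oxidase [flavin-containing] B (Homo sapiens), read by Amplex Red, with a stated time of 15 min; on this read-out higher numbers stand for weaker inhibition and lower numbers for stronger inhibition:

Compound 1, `CC(=O)c1ccc(OCc2ccc([N+](=O)[O-])cc2)cc1`, gives 96.5 nM.
Compound 2, `CC(=O)c1ccc(OCc2ccc(C(F)(F)F)cc2)cc1`, gives 77.8 nM.
Compound 3, `CC(=O)c1cccc(OCc2ccc(C(F)(F)F)cc2)c1`, gives 43.2 nM.

Compounds 1 and 2 share one core and differ only in the group para to a large group on the benzyl ring: nitro in place of trifluoromethyl on an aromatic carbon. This change gave a 1.2-fold higher number from compound 2 to compound 1 (0.09 log units; within the scatter), a step that does not separate the two compounds. Compound 3 carries the same trifluoromethyl-bearing benzyl part as compound 2 on a second core; the difference between the two cores is not broken down here. Compound 3 has the lowest number of the three, but its gap to compound 2 lies within the scatter, so no order between them is claimed. Against compound 1 the gap is beyond the scatter, and only the two values themselves are on record for that pair.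

Compound 4, `CC(=O)c1cccc(OCc2ccc([N+](=O)[O-])cc2)c1`, is the nitro counterpart of compound 3 on the second core: nitro in place of trifluoromethyl on an aromatic carbon. Going by the values given here, the change is the same as the one from compound 2 to compound 1. The only basis for an expectation is that earlier step, which was small, together with the value of compound 3. Compound 4 is therefore expected to give 53 nM in this assay, with a plausible range from 27 nM to 105 nM. That estimate means a 1.2-fold higher number from compound 3 to compound 4 (0.09 log units; within the scatter), a step expected to fall within the scatter, resting on compound 2 to compound 1 having shown a 1.2-fold higher number from compound 2 to compound 1 (0.09 log units; within the scatter) and on compound 3 standing at 43.2 nM. Whether the second core answers the change in the same way is not yet known.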

Compound 4, half-maximal inhibitory concentration: 75.4 nM
Compound 4: middle estimate off by 1.4-fold (0.15 log units), on the low side; the range from low to high includes it.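

In this assay, nitro in place of trifluoromethyl on the core of compound 3 gave a 1.7-fold higher number from compound 3 to compound 4 (0.24 log units; within the scatter) and so does not separate the two compounds. Set beside the earlier step on the core of compound 1, the same change reads alike on the two cores, with no difference between the steps that can be told apart: the same change on two cores in this assay, a 1.2-fold higher number (0.09 log units; within the scatter) from compound 2 to compound 1 and a 1.7-fold higher number (0.24 log units; within the scatter) from compound 3 to compound 4, 1.4-fold (0.15 log units) apart, within the scatter of two such steps

So far, then, this exchange carries from one core to the other without a step that stands clear of the scatter, but that rests on just two pairs and one exchange of groups, and it shows neither a true order between nitro and trifluoromethyl nor that a third core would answer the same way.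

Open, as far as these compounds go, is how other groups at this place on the aromatic ring would read in this assay, for instance a nitrile, an amine or a carboxylic acid, and whether any of them would give a step beyond the scatter on either core. Also open, from the compounds shown here alone, is what happens when the acetyl group gives way to another group, such as an amide, or when the link to the benzyl ring becomes a longer chain.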